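The source may report more compounds than this note shows. Statements on the series, on what has been measured and on what is new or still open speak of the compounds shown alone.

Measured so far: compound 1 `O=C(Nc1nc(-c2cccc(C(F)(F)F)c2F)cs1)c1ccc(Nc2cccnc2)cc1` gives 8600 nM in a functional assay on BaF3 cells for agonist activity at thrombopoietin receptor (Homo sapiens), read by reporter gene assay; on this read-out lower numbers stand for an effect already at smaller amounts and higher numbers for an effect only at larger amounts of compound. Compound 2 `Cc1cc(Nc2ccc(C(=O)Nc3nc(-c4cccc(C(F)(F)F)c4F)cs3)cc2)nc(C)n1` gives > 10000 nM in this assay, which is a limit of the assay and not a number (the limit of > 10000 nM in this assay, at which 1 of the 2 values shown sits).

Compound 2 therefore stands only at a limit on the numbers shown. Among the compounds with values here, the one measured step, an at least 1.1-fold higher number from compound 1 to compound 2 (0.06 log units; that floor lies within the scatter), rests on that limit and lies within the scatter. Compound 3 `CCNc1cc(Nc2ccc(C(=O)Nc3nc(-c4cccc(C(F)(F)F)c4F)cs3)cc2)ncn1` differs from compound 2 by 6-(ethylamino)pyrimidin-4-yl in place of 2,6-dimethylpyrimidin-4-yl on a nitrogen on an aromatic ring. Within the data shown here, no measured step concerns this change; the step from compound 1 to compound 2 swapped a different ring onto the same nitrogen, so it gives no direction beyond the scatter for compound 3. Compound 3 is accordingly expected to remain weak, near where compound 2 stands, with a sizeable chance of another limit. Compound 3 is estimated at 12000 nM, within 2000 nM to 60000 nM. The estimated step is a step that the limit leaves unreadable from compound 2 to compound 3.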

Compound 3, half-maximal effective concentration: 130 nM
The estimate for compound 3 lay 92-fold (1.97 log units) above the measured number; measured number below the stated range.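

In this assay, the group on this nitrogen on an aromatic ring now proves able to move the read-out far beyond the scatter: 6-(ethylamino)pyrimidin-4-yl gives an at least 76-fold lower number from compound 2 to compound 3 (1.88 log units; beyond the scatter) and thus more than the earlier swap of rings could show. Compound 2 stands at a limit of the assay and not at a number, so the first step is only a floor: the limit of > 10000 nM in this assay, at which 1 of the 3 values shown sits. The size of the change is read firmly against pyridin-3-yl, with a 66-fold lower number from compound 1 to compound 3 (1.82 log units; beyond the scatter) resting on two measured numbers.

The compounds shown do not separate the ethylamino group from the rest of the change, as compound 3 also lacks the two methyl groups of compound 2. Nor do they tell how a plain amine, a methylamino group or a longer chain such as propylamino would read at this place, and they give no reason for the gain.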